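The compounds below may be only part of what the source reports. "The series", "measured", "known", "first", "only" and "open" are said of these compounds alone.

The two measured compounds in a functional assay on HepG2 cells (Homo sapiens) for antiproliferative activity, read by MTT assay, with a stated time of 48 h; on this read-out higher numbers stand for weaker inhibition and lower numbers for stronger inhibition:

compound 1 `COc1ccc(-n2nncc2CN2C(=O)C3(C(C#N)=C(N)Oc4c3c3nc5ccccc5nc3c3ccccc43)c3ccccc32)cc1`: > 50000 nM
compound 2 `N#CC1=C(N)Oc2c(N)cc3nc4ccccc4nc3c2C12C(=O)N(Cc1cnnn1-c1ccccc1Cl)c1ccccc12`: 33500 nM

The value given for compound 1 is a limit of the assay and not a number. Among the measured compounds shown here, compound 2 therefore holds the only number in this assay, while the one further value is a limit (the limit of > 50000 nM in this assay, at which 1 of the 2 values shown sits). For the measured compounds named here, no step between two measured compounds is given, so nothing measured bears directly on the change that leads to compound 3 `N#CC1=C(N)Oc2c(N)cc3nc4ccccc4nc3c2C12C(=O)N(Cc1cnnn1-c1ccc([N+](=O)[O-])cc1[N+](=O)[O-])c1ccccc12`. Compound 3 differs from compound 2 in one place (2,4-dinitrophenyl in place of 2-chlorophenyl on an aromatic nitrogen). With no measured comparison to lean on, the step from compound 2 to compound 3 is expected to be a 1.1-fold lower number from compound 2 to compound 3 (0.05 log units; within the scatter), a change that is not expected to reach beyond the usual scatter in either direction. Compound 3 is accordingly estimated at 30000 nM, within a range from 8000 nM to 100000 nM, with a fair chance that the assay again reports only a limit.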

Compound 3, half-maximal inhibitory concentration: 18400 nM
Compound 3: middle estimate off by 1.6-fold (0.21 log units), on the high side, and the stated range covers the measured number.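

In this assay, the aromatic nitrogen of the five-membered ring with 3 nitrogen now yields its first readable step, on exchanging one aryl group for another: a 1.8-fold lower number from compound 2 to compound 3 (0.26 log units; within the scatter). This shows that 2,4-dinitrophenyl can replace 2-chlorophenyl at this position without a change beyond the scatter, even though the entering group is larger by the count of heavy atoms and compound 3 returns a number and not a limit. Nothing among the measurements shown gives a reason for this step.

The compounds shown leave open whether a carboxylic acid or a longer alkyl chain on that nitrogen would move the number beyond the scatter. Among the compounds shown here, compound 1 carries a limit and differs from the others in more than one place, so no step to it can be read.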